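A third aryl swap in a weakly inhibiting series

The source may report more compounds than this note shows. Statements on the series, on what has been measured and on what is new or still open speak of the compounds shown alone.

Compound 1, `COc1ccc(COc2ccc(-c3nn(CCC#N)c(=O)o3)cc2)cc1`, gives 16000 nM in an assay for inhibition of Amine oxidase [flavin-containing] A (Rattus norvegicus); on this read-out higher numbers stand for weaker inhibition and lower numbers for stronger inhibition. Compound 2, `Cc1cccc(COc2ccc(-c3nn(CCC#N)c(=O)o3)cc2)c1`, gives 20000 nM. Compound 3, `Cc1ccc(COc2ccc(-c3nn(CCC#N)c(=O)o3)cc2)cc1`, gives 25000 nM.

All three share one core and differ only in the aryl group carried on a saturated chain carbon bound to an oxygen on an aromatic ring. Compound 3 carries the highest of the three numbers, yet a 1.3-fold higher number from compound 2 to compound 3 (0.10 log units; within the scatter) and a 1.6-fold higher number from compound 1 to compound 3 (0.19 log units; within the scatter) both sit within the scatter, so the three compounds cannot be told apart on this read-out.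

Compound 4, `N#CCCn1nc(-c2ccc(OCc3cccc(Cl)c3)cc2)oc1=O`, has not been measured. Relative to compound 3 it carries 3-chlorophenyl in place of 4-methylphenyl on a saturated chain carbon bound to an oxygen on an aromatic ring. Going by the values given here, two measured steps bear on such an aryl exchange at the same place: a 1.3-fold higher number from compound 1 to compound 2 (0.10 log units; within the scatter) and a 1.3-fold higher number from compound 2 to compound 3 (0.10 log units; within the scatter), each within the scatter. On that basis no step beyond the scatter is expected in this assay for compound 4 in either direction. Compound 4 is therefore estimated at 20000 nM, with a range from 8000 nM to 50000 nM, which would mean an expected step of a 1.3-fold lower number from compound 3 to compound 4 (0.10 log units; within the scatter).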

Compound 4, half-maximal inhibitory concentration: 7400 nM
For compound 4 the middle estimate is 2.7-fold (0.43 log units) above the measured one, outside the stated range (below it).
By their numbers in this assay, from the lowest: compound 4; then compounds 1, 2 and 3 (each within the scatter of the next).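

At this position the aryl group does move the read-out: in this assay, 3-chlorophenyl in place of 4-methylphenyl gives a 3.4-fold lower number from compound 3 to compound 4 (0.53 log units; beyond the scatter), whereas the earlier aryl exchanges all stayed within the scatter. The clearest single change is chloro in place of methyl on the same aromatic carbon, with a 2.7-fold lower number from compound 2 to compound 4 (0.43 log units; beyond the scatter), and the exchange for 4-methoxyphenyl gives a 2.2-fold lower number from compound 1 to compound 4 (0.33 log units; beyond the scatter), so compound 4 stands apart from compounds 1, 2 and 3 with the lowest number of the four. Nothing at hand accounts for this separation.

The compounds shown leave open whether the chloro group counts only as 3-chlorophenyl or would give a similar step as 4-chlorophenyl. They also leave open whether 3-fluorophenyl or 3-bromophenyl would follow 3-chlorophenyl on this read-out.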